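This account rests on a few compounds, and the source may have more. Where it says the series, first, only, none or still open, it means among the compounds named here.

Measured in a functional assay on WiDr cells (Homo sapiens) for inhibition, read by sulforhodamine B assay, with a stated time of 48 h; a higher number here means a weaker inhibitor of growth, a lower number a stronger inhibitor of growth:
- compound 1 `CCCOC(=[Se])Nc1ccc2c(C)cc(=O)oc2c1`: 42000 nM
- compound 2 `CCCCOC(=[Se])Nc1ccc2c(C)cc(=O)oc2c1`: "nd(insoluble)" (no result reported)

Compound 2 has no place on the numerical scale. Its entry reads "nd(insoluble)" (no result reported), so no concentration for growth inhibition was reported, and it cannot be ranked against compound 1. For the measured compounds named here, the only number available is therefore the one for compound 1, at 42000 nM.

The next compound is compound 3 `Cc1cc(=O)oc2cc(NC(=[Se])Nc3ccccc3)ccc12`, which is yet to be tested. The structural change is anilino in place of butoxy on a saturated chain carbon bound to a nitrogen on an aromatic ring. Going by the values given here, no measured pair shows what such a change does, so any expectation is loosely anchored. Among the compounds with values here, with no measured step from compound 2, the direction in this assay can only be judged against compound 1 at 42000 nM. A moderate step toward stronger growth inhibition is expected from that value, though a result close to it would be no surprise. For compound 3 the estimated value is 15000 nM, with an expected range of 3000 nM to 60000 nM.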

Compound 3, concentration for 50% growth inhibition: 34000 nM
Compound 3: the middle estimate sits 2.3-fold (0.36 log units) below what was measured, within the range that was stated.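

In this assay, putting anilino where propoxy stood gives a 1.2-fold lower number from compound 1 to compound 3 (0.09 log units; within the scatter), so the two compounds read as equal in growth inhibition. This position therefore accepts a group carrying a six-membered aromatic ring of carbon only and a hydrogen-bond donor with no change in the reading beyond the scatter, which compound 1 alone could not show. The step from compound 2, with its butoxy group, cannot be read, and no measurement here offers a reason why the reading stays where it stood.

The compounds shown leave open whether any group at this position can move growth inhibition beyond the scatter, since the one readable step does not. An anilino ring bearing a chlorine or a methoxy group, a benzylamino group or a shorter chain such as ethoxy could each test this, and the shared core may matter more than this position, a question these compounds do not touch.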